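Cytotoxicity on bovine kidney cells: halogenated benzyl variants

A few compounds are considered here, and "the series" means these few. Any claim that something is new, unique, unknown or untested is made for them only; others in the source may bear on it.

Measured compounds:
- compound 1, `Cc1cccc(Cn2ccc3nc(-c4ccccc4)nc-3c2)c1`, in an ADME assay on MDBK cells (Bos taurus) for cytotoxicity (on this read-out lower numbers stand for higher toxicity in this test and higher numbers for lower toxicity in this test), compound 1 gives > 100000 nM, a limit of the assay.
- compound 2, `Fc1cccc(Cn2ccc3nc(-c4ccccc4)nc-3c2)c1`; in this assay compound 2 gives > 100000 nM, again a limit.
- compound 3, `Clc1ccccc1Cn1ccc2nc(-c3ccccc3)nc-2c1`; in this assay compound 3 gives > 100000 nM, also a limit.

Compound 3 therefore has no number of its own in this assay, only a limit, and the two other values shown are limits of the same kind. The steps between the measured compounds cannot be read: a step that the two limits leave unreadable from compound 1 to compound 2, a step that the two limits leave unreadable from compound 1 to compound 3 and a step that the two limits leave unreadable from compound 2 to compound 3 all fall between values that are limits, so their size is not known. Within the data shown here, the one piece of evidence that holds across the set is the limit of > 100000 nM in this assay, at which 3 of the 3 values shown sit.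

The next compound is compound 4, `Ic1ccc(Cn2ccc3nc(-c4ccccc4)nc-3c2)cc1`. It differs from compound 3 as follows: 4-iodophenyl in place of 2-chlorophenyl on a saturated chain carbon bound to an aromatic nitrogen. Among the measured compounds shown here, none of the measured steps gives a readable size that bears on this change, since every value sits at the limit. The expectation for compound 4 is therefore an unreadable step, a step that the limit leaves unreadable from compound 3 to compound 4, with the value most likely reported as a limit again. Compound 4 is estimated at 150000 nM in this assay, with a range from 80000 nM to 400000 nM.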

Compound 4, half-maximal cytotoxic concentration: 22000 nM
Compound 4: middle estimate off by 6.8-fold (0.83 log units), on the high side; measured number below the stated range.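

In this assay, the group on a saturated chain carbon bound to an aromatic nitrogen now proves able to shift the read-out, with 4-iodophenyl in place of 2-chlorophenyl giving an at least 4.5-fold lower number from compound 3 to compound 4 (0.65 log units; beyond the scatter). The same holds against the other two groups, with an at least 4.5-fold lower number from compound 2 to compound 4 (0.65 log units; beyond the scatter) and an at least 4.5-fold lower number from compound 1 to compound 4 (0.65 log units; beyond the scatter), so compound 4 is the only compound shown with a number of its own rather than a limit. The steps among compound 1, compound 2 and compound 3 remain unreadable, and the three steps to compound 4 give minimum sizes only, because the other values are limits: the limit of > 100000 nM in this assay, at which 3 of the 4 values shown sit.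

Since 4-iodophenyl differs from the other groups in both the substituent and its place on the ring, the compounds shown do not separate the contribution of the iodine from that of its place. Going by these compounds, how far the number would move with an amine or a carboxylic acid on this phenyl ring also remains open.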